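Anilino to pyrimidinylamino: a single exchange on the amine

The compounds below may be only part of what the source reports. "The series", "measured", "known", "first", "only" and "open" are said of these compounds alone.

Measured compounds:
- compound 1, `CC(=O)c1cc(C(=O)N[C@H](C)Cn2ccc(-c3cc(F)c(C#N)c(Cl)c3)n2)n[nH]1`: "not determined" (no result reported)
- compound 2, `C[C@@H](Cn1ccc(-c2ccc(C#N)c(Cl)c2)n1)Nc1ccccc1`: 3210 nM

Going by the values given here, in an ADME assay on PC-3 cells (Homo sapiens) for cytotoxicity, read by CCK-8 assay, with a stated time of 6 days (on this read-out higher numbers stand for weaker inhibition and lower numbers for stronger inhibition), compound 2 gives 3210 nM, the only number reported here. Compound 1 was entered without a result, "not determined" (no result reported), so no comparison with it can be drawn. Compound 3, `Cc1ccnc(N[C@@H](C)Cn2ccc(-c3ccc(C#N)c(Cl)c3)n2)n1`, differs from compound 2 by 4-methylpyrimidin-2-yl in place of phenyl on an amine nitrogen. Among the compounds with values here, with no measured pair to set the size of such an exchange, the step from compound 2 to compound 3 is expected to stay within the usual scatter, with no clear direction. Compound 3 is therefore estimated at 2800 nM, between 900 nM and 9000 nM, which means an expected step of a 1.1-fold lower number from compound 2 to compound 3 (0.06 log units; within the scatter).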

Compound 3, half-maximal inhibitory concentration: > 30000 nM
Compound 3 was reported as a limit; the forecaster's own chance of this, stated with the estimate: 10%; middle value at least 10-fold (1.02 log units) away from the limit.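

Going by these compounds alone, exchanging phenyl for 4-methylpyrimidin-2-yl on the amine nitrogen in this assay gives an at least 9.3-fold higher number from compound 2 to compound 3 (0.97 log units; beyond the scatter), the first measured step here, and it shows that the read-out is not indifferent to the group at this place. The entry for compound 3 is a limit of the assay, not a number: the limit of > 30000 nM in this assay, at which 1 of the 3 values shown sits.

The compounds shown leave open whether the step goes with the ring nitrogens or with the methyl group. An unsubstituted pyrimidin-2-yl or a pyridin-2-yl on the same amine nitrogen would separate the two.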